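A few compounds are considered here, and "the series" means these few. Any claim that something is new, unique, unknown or untested is made for them only; others in the source may bear on it.

Compound 1 `Cn1cc(-c2ccccc2NCC2=NCCN2)cn1` and compound 2 `CCn1cc(-c2ccccc2NCC2=NCCN2)cn1` share a core that carries an aminomethyl-imidazoline side chain, and both are tested in a functional assay with Alpha-1B adrenergic receptor (Homo sapiens) as the target, read by calcium flux; on this read-out lower numbers stand for smaller maximal responses and higher numbers for larger maximal responses. In that assay compound 1 gives 0%, and compound 2 gives 0%. The one measured step, methyl in place of hydrogen on a saturated chain carbon bound to an aromatic nitrogen, gives no change at the digits printed from compound 1 to compound 2 (within the scatter), so compound 1 stands level with compound 2 at the digits shown.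

Compound 3 `c1ccc(-c2nc[nH]n2)c(NCC2=NCCN2)c1` is not yet measured. It differs from compound 1 by 1H-1,2,4-triazol-3-yl in place of 1-methyl-1H-pyrazol-4-yl on an aromatic carbon. Among the measured compounds shown here, no measured step touches that position, so the step from compound 1 to compound 2 bears on it only in showing that the series sits at the floor of the read-out. On that basis, the change in compound 3 is estimated to give no change at the digits printed from compound 1 to compound 3 (within the scatter), and compound 3 is expected to reach 0%, with a range from 0% to 15%.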

Compound 3, largest response reached (reported as maximal response), in percent of the reference or control that the assay uses: 100%
Beside the measured number, compound 3's estimate is 100 percentage points below it, and the stated range ends below it.
By their numbers in this assay, from the lowest: compounds 1 and 2 (each within the scatter of the next); then compound 3.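

The aromatic carbon ortho to a group of 7 heavy atoms is a position that moves the response in this assay: 1H-1,2,4-triazol-3-yl in place of 1-methyl-1H-pyrazol-4-yl gives a number 100 percentage points higher from compound 1 to compound 3 (beyond the scatter). The earlier step, made on the chain of the pyrazole nitrogen, left the series at the floor of the read-out, whereas this exchange of the whole ring lifts it clear of that floor. Nothing at hand accounts for the size of this step.

The exchange alters the ring's hetero atoms, removes the methyl and brings in 1 hydrogen-bond donor against 0, all at once, so the compounds shown do not separate these changes. From the compounds shown here alone, whether an unsubstituted 1H-pyrazol-4-yl, a carboxylic acid or an amine on this carbon would also raise the response remains open.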